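The source may report more compounds than this note shows. Statements on the series, on what has been measured and on what is new or still open speak of the compounds shown alone.

- compound 1 `Cc1c(C)c2c(c(C)c1OC(=O)CCC(=O)O)CCC(C)(C(=O)NCC1CC(C)(C)N([O])C1(C)C)O2`: > 300000 nM (a limit)
- compound 2 `Cc1c(C)c2c(c(C)c1OC(=O)CCC(=O)O)CCC(C)(C(=O)O)O2`: > 300000 nM (a limit)

In a toxicity assay on cells (Cricetulus griseus) for cytotoxicity, read by MTT assay, with a stated time of 72 h (on this read-out higher numbers stand for weaker inhibition and lower numbers for stronger inhibition), compound 1 gives > 300000 nM, which is a limit and not a number. Compound 3 `Cc1c(C)c2c(c(C)c1OC(=O)CCC(=O)NCC1CC(C)(C)N([O])C1(C)C)CCC(C)(C(=O)NCC1CC(C)(C)N([O])C1(C)C)O2` differs from it as follows: a group of 12 heavy atoms (9 carbon, 2 nitrogen, 1 oxygen; one five-membered non-aromatic ring with 1 hetero atom) in place of one oxygen atom, on a carbonyl carbon. Among the compounds with values here, one measured step bears on this change, since it swaps such a group for one oxygen atom on a carbonyl carbon: a step that the two limits leave unreadable from compound 1 to compound 2. Both measured compounds sit at the limit of > 300000 nM in this assay, at which 2 of the 2 values shown sit, so that step has no readable size. No shift beyond the scatter is therefore expected in this assay, and the estimated step is a number no higher from compound 1 to compound 3 (the limit leaves the size open). The expected value for compound 3 is 300000 nM, with an estimated range of 100000 nM to 600000 nM.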

Compound 3, half-maximal inhibitory concentration: 50000 nM
Compound 3: middle estimate off by 6.0-fold (0.78 log units), on the high side, and the stated range ends above it.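

In this assay, replacing the hydroxy on this carbonyl carbon with the 12-atom group gives an at least 6.0-fold lower number from compound 1 to compound 3 (0.77 log units; beyond the scatter), so this change can move the read-out in the direction of stronger inhibition. The earlier step between compound 1 and compound 2 cannot be read. This new step has only a minimum size, since compound 1 gives a limit and not a number: the limit of > 300000 nM in this assay, at which 2 of the 3 values shown sit.

Going by these compounds, whether a simple amino group or a short carbon chain at this place would have a similar effect stays open. So does how much of the step depends on the five-membered ring of the group.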